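Benzoyl removal from compound 1: working notes

A few compounds are considered here, and "the series" means these few. Any claim that something is new, unique, unknown or untested is made for them only; others in the source may bear on it.

In a functional assay on MRC5 cells (Homo sapiens) for cytotoxicity, read by MTT assay, with a stated time of 48 h (a lower number here means a stronger inhibitor, a higher number a weaker inhibitor), compound 1 (`O=C(O[C@H]1C[C@H](n2cc(F)c(=O)[nH]c2=O)O[C@@H]1COP(=O)(O)Oc1ccc2ncccc2c1)c1ccccc1`) gives 1300 nM and stands lowest of the three measured numbers. Compound 2 (`C[n+]1cccc(OP(=O)([O-])OC[C@H]2O[C@@H](n3cc(F)c(=O)[nH]c3=O)C[C@@H]2OC(=O)c2ccccc2)c1`) comes in at 5750 nM on the same scale and compound 3 (`O=C(O[C@H]1C[C@H](n2cc(F)c(=O)[nH]c2=O)O[C@@H]1COP(=O)([O-])Oc1ccc[n+](Cc2ccccc2)c1)c1ccccc1`) at 38500 nM on that scale too.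

Compound 4 (`O=c1[nH]c(=O)n([C@H]2C[C@H](O)[C@@H](COP(=O)(O)Oc3ccc4ncccc4c3)O2)cc1F`) is not yet measured. It departs from compound 1 by a single change (hydrogen in place of benzoyl on an oxygen on a saturated carbon) that reads benzoyloxy to hydroxy, with hydrogen in place of benzoyl on an oxygen on a saturated carbon.

For the measured compounds named here, only one measured step exists (a 6.7-fold higher number from compound 2 to compound 3 (0.83 log units; beyond the scatter)) and it is phenyl in place of hydrogen on a saturated chain carbon bound to an aromatic nitrogen. It lies elsewhere in the structure, so it bears on the present change only loosely. Going by the values given here, no measured pair removes the benzoyl, and the direction remains poorly fixed. Among the compounds with values here, with the step to compound 3 (a 6.7-fold higher number from compound 2 to compound 3 (0.83 log units; beyond the scatter)) as the sole guide, where adding a phenyl-bearing group went with a higher number, loss of the benzoyl is tentatively expected to lower the number slightly. An estimated step of small size (a 2.2-fold lower number from compound 1 to compound 4 (0.34 log units; beyond the scatter)) is expected, and a step the other way cannot be excluded. The estimated value for compound 4 is 600 nM within an expected range of 100 nM to 3500 nM in this read-out.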

Compound 4, half-maximal inhibitory concentration in the MRC5 assay: 1300 nM
For compound 4 the middle estimate is 2.2-fold (0.34 log units) below the measured one; low and high end bracket the measured number.
By their numbers in the MRC5 assay, from the lowest: compounds 1 and 4 (each within the scatter of the next); then compound 2; then compound 3.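

Compounds 1 to 3 all carry the benzoyloxy group, so none of them could show what this position contributes. Hydrogen in place of benzoyl on an oxygen on a saturated carbon now shows that in the MRC5 assay the group can go with no change at the digits printed from compound 1 to compound 4 (within the scatter), which means that removing all of the benzoyl, ring included, leaves this read-out where it was for the core of compound 1. The same change does register in a physicochemical assay for metabolic stability, read by HPLC, tested at 2 mM (on this read-out lower numbers stand for a shorter-lived compound and higher numbers for a longer-lived compound), where compound 1 gives 7.7 h and compound 4 gives 26 h and so the two read-outs part at this position, with the hydroxy of compound 4 going with the longer-lived compound and the benzoyloxy of compound 1 with the shorter-lived one: the measured half-life of compound 1, 7.7 h, and of compound 4, 26 h, a 3.4-fold higher number (0.53 log units; beyond the scatter)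

Only benzoyloxy and hydroxy are shown at this oxygen, so it remains open whether a smaller acetyl, a longer alkyl ester chain or an amine in place of the oxygen would likewise leave the MRC5 assay unmoved while shifting the half-life. Also open, going by these compounds, is whether benzoyl removal from compound 2 or compound 3 would follow the same course in both read-outs.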